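The source may hold more compounds than are shown below. What is called first, only, known or untested is meant among the compounds shown, and "the series" means these compounds.

Series notes. Compound 1 `COc1ccccc1-c1n[nH]cc1N1CCCNCC1`, compound 2 `COc1ccccc1-c1n[nH]cc1N1CCNCC1` and compound 3 `COc1cccc(-c2n[nH]cc2N2CCNCC2)c1` share a core and differ only in the substitution pattern of the aromatic ring and the size of the amine ring. In an assay on isolated protein for binding affinity to 5-hydroxytryptamine receptor 4 (Homo sapiens) (a lower number here means a stronger inhibitor, a higher number a weaker inhibitor), compound 1 gives > 10000 nM, a limit of the assay rather than a number. Compound 2 gives > 10000 nM in this assay, again a limit. Compound 3 gives > 10000 nM in this assay, also a limit. Compound 3 therefore stands at the limit of > 10000 nM in this assay, at which 3 of the 3 values shown sit, with no measured number to separate it from the others. Compound 4 `c1ccc(-c2n[nH]cc2N2CCNCC2)cc1` is not yet measured and differs from compound 3 by hydrogen in place of methoxy on an aromatic carbon. Among the measured compounds shown here, no measured step covers this change, and no step beyond the usual scatter is expected in this assay. Compound 4 is estimated at 20000 nM (range 5000 nM to 100000 nM), most likely reported as a limit again. This expectation corresponds to a step that the limit leaves unreadable from compound 3 to compound 4.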

Compound 4, inhibition constant: > 10000 nM
Compound 4: only a limit was reported; the forecaster's own chance of this, stated with the estimate: 85%; the middle value does not contradict the limit.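

The steps from compound 2 and from compound 3 to compound 4 cannot be read, since all three compounds give only limits in this assay. The compounds shown leave open what any aromatic-ring or amine-ring change does to a measurable value: the limit of > 10000 nM in this assay, at which 4 of the 4 values shown sit.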